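The source may hold more compounds than are shown below. What is called first, only, known or untested is meant among the compounds shown, and "the series" means these compounds.

Measured so far:
- compound 1, `COc1cc2c(Oc3c(F)cc(NC(=O)NN4C(=O)CSC4c4c(F)cccc4F)cc3F)ccnc2cc1OCCCN1CCN(C)CC1`: 510 nM
- compound 2, `COc1cc2c(Oc3c(F)cc(NC(=O)NN4C(=O)CSC4c4c(F)cccc4F)cc3F)ccnc2cc1OCCCN1CCC(N2CCCCC2)CC1`: 380 nM

Both compounds share one core and differ only in the amine at the end of the side chain. In a functional assay on A549 cells (Homo sapiens) for antiproliferative activity, read by MTT assay, with a stated time of 72 h (on this read-out higher numbers stand for weaker inhibition and lower numbers for stronger inhibition), compound 1 gives 510 nM and compound 2 gives 380 nM. Going by the values given here, the single measured step, a 1.3-fold lower number from compound 1 to compound 2 (0.13 log units; within the scatter), means the two cannot be told apart on these numbers, so compound 2 does not stand out from compound 1.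

Compound 3, `CCN1CCN(CCCCOc2cc3nccc(Oc4c(F)cc(NC(=O)NN5C(=O)CSC5c5c(F)cccc5F)cc4F)c3cc2OC)CC1`, carries the change ((4-ethylpiperazin-1-yl)methyl in place of 4-(piperidin-1-yl)piperidin-1-yl on a saturated chain carbon, three bonds along the chain from an oxygen on an aromatic ring). Among the compounds with values here, the only step that bears on this is the one from compound 1 to compound 2, which swapped one amine for another at the same place and stayed within the scatter. A further amine swap at that place is therefore expected to move the number little, if at all, so for compound 3 the expected step is a 1.2-fold higher number from compound 2 to compound 3 (0.07 log units; within the scatter). The estimated value of compound 3 in this assay is 450 nM, with a range from 200 nM to 1000 nM.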

Compound 3, half-maximal inhibitory concentration: 1390 nM
Compound 3: middle estimate off by 3.1-fold (0.49 log units), on the low side; the measured number lies above the stated range.
By their numbers in this assay, from the lowest: compounds 2 and 1 (each within the scatter of the next); then compound 3.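

In this assay the amine at this place does matter after all: bringing in (4-ethylpiperazin-1-yl)methyl gives a 3.7-fold higher number from compound 2 to compound 3 (0.56 log units; beyond the scatter) and also a 2.7-fold higher number from compound 1 to compound 3 (0.44 log units; beyond the scatter) so compound 3 is the weakest of the three, whereas the earlier swap stayed within the scatter. Both steps are modest, but they show that a change on a saturated chain carbon, three bonds along the chain from an oxygen on an aromatic ring, is not always silent. Nothing available here gives a reason for this loss of activity.

Going by these compounds, compound 3 differs from compound 1 in both the ethyl group and the added methyl unit, so which of them goes with the higher number stays open, and (4-methylpiperazin-1-yl)methyl at the same place would help separate the two. On these data alone, how a morpholine would fare there also remains open.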